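Replacing a Cycloheptenyl Ring with a Methoxyphenyl Group

This account rests on a few compounds, and the source may have more. Where it says the series, first, only, none or still open, it means among the compounds named here.

Among the three measured compounds, compound 3 `CC(C)C[C@H](N)CN(C(=O)[C@@H]1C[C@H]1c1ccccc1)c1ccc(C2=CCCCCC2)cc1` carries the highest number in a functional assay for agonist activity at G protein-coupled receptor 88 (Homo sapiens), read by HTRF and cAMP accumulation (a lower number here means that less compound is needed, a higher number that more compound is needed for the effect), at 2100 nM. Its closest neighbour is compound 2 `CC(C)C[C@H](N)CN(C(=O)[C@@H]1C[C@H]1c1ccccc1)c1ccc(C2=CCCC2)cc1`, which gives 1200 nM; the change a 1.8-fold higher number from compound 2 to compound 3 (0.24 log units; within the scatter) is within the scatter, so the two cannot be ordered. Compound 1 `CC[C@H](C)[C@H](N)CN(C(=O)[C@@H]1C[C@H]1c1ccc(F)c(F)c1)c1ccc(-c2ccccc2)cc1` differs from compound 3 in several places at once; compound 1 gives 720 nM, and that gap lies beyond the scatter.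

Compound 4 `COc1ccc(-c2ccc(N(C[C@@H](N)CC(C)C)C(=O)[C@@H]3C[C@H]3c3ccccc3)cc2)cc1` arises from compound 3 by a single change: 4-methoxyphenyl in place of cyclohept-1-en-1-yl on an aromatic carbon. Among the measured compounds shown here, no measured step exchanges a non-aromatic ring for an aromatic one at this aromatic carbon; the only nearby pointer is the step from compound 2 to compound 3, which enlarged the non-aromatic ring and stayed within the scatter. Compound 1, whose group on that aromatic carbon is also aromatic, has the lowest number, but it differs elsewhere too. Compound 4 is therefore expected to show a step of a 1.9-fold lower number from compound 3 to compound 4 (0.28 log units; within the scatter) in this assay, near the starting number or somewhat lower. The estimate for compound 4 is 1100 nM, with a range from 350 nM to 3500 nM.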

Compound 4, half-maximal effective concentration: 330 nM
For compound 4 the middle estimate is 3.3-fold (0.52 log units) above the measured one; measured number below the stated range.
By their numbers in this assay, from the lowest: compound 4; then compounds 1, 2 and 3 (each within the scatter of the next, the first and the last beyond it).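

In this assay, 4-methoxyphenyl on this aromatic carbon gives a clearly lower number than either non-aromatic ring (a 6.4-fold lower number from compound 3 to compound 4 (0.80 log units; beyond the scatter); a 3.6-fold lower number from compound 2 to compound 4 (0.56 log units; beyond the scatter)). The earlier compounds had shown only a change in the size of the non-aromatic ring (a 1.8-fold higher number from compound 2 to compound 3 (0.24 log units; within the scatter)), so this is the first one-place change here to show that the group at this carbon can move the number beyond the scatter. The change swaps a non-aromatic ring for an aromatic one and also brings in an oxygen, and no evidence here explains the drop.

The compounds shown leave open whether the aromatic ring alone accounts for the lower number, which a plain phenyl on the core of compound 4 would test. They also leave open whether a hydroxyl or a dimethylamino group could take the place of the methoxy group.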